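This account rests on a few compounds, and the source may have more. Where it says the series, first, only, none or still open, it means among the compounds named here.

In a functional assay on COLO 205 cells (Homo sapiens) for inhibition, read by sulforhodamine B assay, with a stated time of 48 h, tested at 50 uM (on this read-out lower numbers stand for less inhibition of growth and higher numbers for more inhibition of growth at the one concentration tested), two compounds sharing one core have been measured so far. Compound 1 `COc1cc(/C=C/C(=O)/C=C/c2cccc3ccccc23)ccc1OCc1cn(CCCOc2cc(=O)oc3ccccc23)nn1` gives 64%, and compound 2 `COc1cccc(/C=C/C(=O)/C=C/c2ccc(OCc3cn(CCCOc4cc(=O)oc5ccccc45)nn3)c(OC)c2)c1` gives 52%, the lower of the two numbers. Between them lies a number 12 percentage points lower from compound 1 to compound 2 (beyond the scatter), with 3-methoxyphenyl in place of naphthalen-1-yl.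

Compound 3 `COc1ccc(/C=C/C(=O)/C=C/c2ccc(OCc3cn(CCCOc4cc(=O)oc5ccccc45)nn3)c(OC)c2)cc1` has not yet been measured. It departs from compound 2 by 4-methoxyphenyl in place of 3-methoxyphenyl on a double-bonded chain carbon bound to a double-bonded chain carbon; the two have the same atoms, joined differently, with 4-methoxyphenyl in place of 3-methoxyphenyl on a double-bonded chain carbon bound to a double-bonded chain carbon.

Among the compounds with values here, the one measured step, a number 12 percentage points lower from compound 1 to compound 2 (beyond the scatter), bears on this change, as it falls at the same place. Within the data shown here, it exchanged a different group, however, and no measured pair compares 3-methoxyphenyl with 4-methoxyphenyl. The new change is therefore expected to produce a smaller step than that one, with no firm direction and probably nothing beyond the scatter. The expected change is a number 3 percentage points higher from compound 2 to compound 3 (within the scatter). For compound 3 the estimated value is 55%, with an expected range of 42% to 68%.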

Compound 3, percent growth inhibition at one concentration: 53%
The estimate for compound 3 lay 2 percentage points above the measured number; the measured number falls inside the stated range.
By their numbers in this assay, from the lowest: compounds 2 and 3 (each within the scatter of the next); then compound 1.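

In this assay, 4-methoxyphenyl in place of 3-methoxyphenyl gives a number 1 percentage points higher from compound 2 to compound 3 (within the scatter) on a double-bonded chain carbon bound to a double-bonded chain carbon, so the two arrangements of the same atoms cannot be told apart at this place. The comparison with naphthalen-1-yl now rests on two methoxyphenyl groups rather than one: 4-methoxyphenyl in place of naphthalen-1-yl gives a number 11 percentage points lower from compound 1 to compound 3 (beyond the scatter) in this read-out, in the same direction as a number 12 percentage points lower from compound 1 to compound 2 (beyond the scatter) for 3-methoxyphenyl. Among the three compounds, then, the exchange of naphthalen-1-yl for a methoxyphenyl group matters beyond the scatter, while the choice between the two methoxyphenyl groups does not. Nothing shown here gives a reason for these numbers.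

On these data alone, whether a phenyl group carrying a dimethylamino group or a carboxylic acid at this place would fall with compound 1 or with compound 2 and compound 3 stays open. So does whether these relations hold at any concentration other than the one tested.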